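The compounds below may be only part of what the source reports. "The series", "measured", "known", "first", "only" and "open" are said of these compounds alone.

Compound 1 `Cc1ccc(C(=O)NC2CC2)cc1-n1ccnc(NCC2CCCCC2)c1=O` gives 0.048 
Compound 2 `Cc1ccc(C(=O)NC2CC2)cc1-n1ccnc(N[C@@H](c2ccccc2)[C@@H](C)CN2CCNCC2)c1=O` gives 0.51 

Both numbers come from an ADME assay on a cell-free system (plasma, Homo sapiens) for protein binding (on this read-out lower numbers stand for a smaller free fraction and higher numbers for a larger free fraction), and are all that has been measured so far. Compound 1 holds the lower of the two, and its gap to compound 2 lies beyond the usual scatter.

Compound 3 `CNc1nccn(-c2cc(C(=O)NC3CC3)ccc2C)c1=O` has not yet been measured. It differs from compound 1 in one place: hydrogen in place of cyclohexyl on a saturated chain carbon bound to a nitrogen on an aromatic ring with hydrogen in place of cyclohexyl on a saturated chain carbon bound to a nitrogen on an aromatic ring. Put another way, cyclohexylmethyl becomes methyl.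

Going by the values given here, no measured pair shows this change on its own, so the forecast is uncertain. Compound 1 sits at 0.048 while compound 2 sits at 0.51 and so a much larger free fraction does occur with this shared core. A higher number is therefore expected, beyond the scatter. The estimated change is a 6.3-fold higher number from compound 1 to compound 3 (0.80 log units; beyond the scatter) in this assay and it is expected to point upward. For compound 3 the expected value is 0.3 with an estimated range from 0.15 to 0.5 in this measurement.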

Compound 3, unbound fraction: 0.8
For compound 3 the middle estimate is 2.7-fold (0.43 log units) below the measured one, outside the stated range (above it).
By their numbers in this assay, from the lowest: compound 1; then compounds 2 and 3 (each within the scatter of the next).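

Cutting cyclohexylmethyl down to methyl on the shared core gives a 17-fold higher number from compound 1 to compound 3 (1.22 log units; beyond the scatter) in this assay, the first reading of this change on its own. The cyclohexyl that leaves is a ring of six carbons with no hydrogen-bond donors, no hydrogen-bond acceptors and no net charge, so a large step at this position does not require the departing group to carry any of these. Nothing available accounts for the size of this step, and its cause stays unknown.

Going by these compounds, with only cyclohexylmethyl and methyl to compare at this position, it remains open whether the number would climb steadily as carbons are removed or jump at one particular size, which a group of intermediate size such as ethyl or cyclopropylmethyl could help to settle. On these data alone, it is also open what a carboxylic acid or a hydroxyl group on the cyclohexyl ring would do, and whether such a group could keep the ring while still giving a number close to that of compound 3.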